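A few compounds are considered here, and "the series" means these few. Any claim that something is new, unique, unknown or untested is made for them only; others in the source may bear on it.

Measured so far:
Compound 1, `COc1ccc(C(c2ccc(OC)cc2)C2CCN(CCCOc3ccc(C(C)=O)cc3OC)CC2)cc1`, gives 10 nM in a functional assay (aorta) with Oryctolagus cuniculus as the target; a higher number here means weaker binding, a lower number tighter binding.
Compound 2, `COc1cc(C(C)=O)ccc1OCCCN1CCC(C(c2ccc(F)cc2)c2ccccn2)CC1`, gives 158 nM in this assay.
Compound 3, `CC(=O)c1ccc(OCCCN2CCC(C(c3ccc(F)cc3)c3ccc(F)cc3)CC2)cc1`, gives 2.51 nM in this assay.

Compound 3 has the lowest number of the three; compound 1 stands nearest to it and compound 2 furthest, and both gaps are beyond the scatter, so compound 3 is the tightest binder of the set as measured. Compound 4, `Fc1ccc(C(c2ccc(F)cc2)C2CCN(CCCOc3ccccc3)CC2)cc1`, has not been measured. It differs from compound 3 in one place: hydrogen in place of acetyl on an aromatic carbon.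

Within the data shown here, no measured pair in this set differs only in the acetyl group, so the size of this step cannot be read from the numbers directly. Compound 1 and compound 2 carry the acetyl with other changes besides, and their numbers are higher than that of compound 3 for reasons not separable here. Compound 4 is expected to give a somewhat higher number than compound 3, a step of a 3.2-fold higher number from compound 3 to compound 4 (0.50 log units; beyond the scatter) in this assay. Compound 4 is thus estimated at 8 nM in this assay, within a range from 2.5 nM to 25 nM.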

Compound 4, dissociation constant: 1.59 nM
Beside the measured number, compound 4's estimate is 5.0-fold (0.70 log units) above it; measured number outside the range, below it.
By their numbers in this assay, from the lowest: compounds 4 and 3 (each within the scatter of the next); then compound 1; then compound 2.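

Among these compounds, exchanging the acetyl group on this aromatic carbon, para to a large group, for hydrogen gives a step that can be read directly for the first time (a 1.6-fold lower number from compound 3 to compound 4 (0.20 log units; within the scatter)) in this assay. Among the compounds shown here, on this core, then, the acetyl group is not needed for a number this low, and 4-acetylphenoxy and phenoxy cannot be told apart here, which the earlier compounds, differing in several places at once, could not show. Nothing given here explains this result.

On these data alone, it remains open whether an amine, a carboxylic acid or a methoxy group on the same carbon would also leave the number within the scatter of these two. Also open, as far as these compounds go, is whether hydrogen in place of acetyl would give a similar step on the cores of compound 1 and compound 2.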